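The source may hold more compounds than are shown below. What is called first, only, known or untested is meant among the compounds shown, and "the series" means these compounds.

- compound 1 `CC/C=C/C(=O)N(Cc1ccc(OC)c(O)c1)c1cc(OC)c(OC)c(OC)c1` gives 63 nM
- compound 2 `COc1ccc(CN(C(=O)C[Se]C#N)c2cc(OC)c(OC)c(OC)c2)cc1O` gives 310 nM

In a functional assay on HCT-116 cells (Homo sapiens) for inhibition, read by MTT assay, with a stated time of 48 h (on this read-out higher numbers stand for weaker inhibition and lower numbers for stronger inhibition), compound 2 at 310 nM holds the higher of the two numbers. A single measured step bears on the next change and sits on the same carbonyl carbon: a 4.9-fold higher number from compound 1 to compound 2 (0.69 log units; beyond the scatter) is a modest step beyond the scatter. Compound 3 `COc1ccc(CN(C(=O)C2CC2)c2cc(OC)c(OC)c(OC)c2)cc1O` differs from compound 2 only in this group: a group of 3 heavy atoms (3 carbon; one three-membered non-aromatic ring of carbon only) in place of a group of 4 heavy atoms (2 carbon, 1 nitrogen, 1 selenium; no ring), on a carbonyl carbon describes the change, with cyclopropyl entering on a carbonyl carbon whose other neighbours are: amide-type nitrogen. Compound 1 carries a group of 4 carbon at this place and gives 63 nM in the same read-out. A move towards a lower number is therefore expected in this assay, no larger than the measured step. One step is thin support, so the range is kept wide. The expected change is a 2.4-fold lower number from compound 2 to compound 3 (0.38 log units; beyond the scatter) as an estimate. For compound 3 the estimated value is 130 nM with an expected range of 35 nM to 500 nM in this read-out.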

Compound 3, half-maximal inhibitory concentration: 49 nM
Compound 3: the middle estimate sits 2.7-fold (0.42 log units) above what was measured; measured number inside the range.
By their numbers in this assay, from the lowest: compounds 3 and 1 (each within the scatter of the next); then compound 2.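

In this assay, replacing the selenium-containing group on the carbonyl carbon with cyclopropyl gives a 6.3-fold lower number from compound 2 to compound 3 (0.80 log units; beyond the scatter), so the gap seen earlier is no longer a comparison with but-1-en-1-yl alone. Set against but-1-en-1-yl, cyclopropyl gives a 1.3-fold lower number from compound 1 to compound 3 (0.11 log units; within the scatter), so at this place these two all-carbon groups, one a ring and one without a ring, cannot be told apart in this read-out. No measurement at hand accounts for these differences.

The compounds shown leave open whether the selenium atom or the nitrile goes with the higher number of compound 2, a question that a matching sulfur-containing group would address. As far as these compounds go, how an amine, a carboxylic acid or a longer chain would read on the same carbonyl carbon also remains open.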